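Replacing the pyridin-3-yl ester of compound 2 with acetate

A few compounds are considered here, and "the series" means these few. Any claim that something is new, unique, unknown or untested is made for them only; others in the source may bear on it.

Measured so far: compound 1 `C=C1CC[C@@H]2[C@](C)(COC(=O)/C=C/c3cc(OC)c(OC)c(OC)c3)[C@H](O)CC[C@@]2(C)[C@@H]1/C=C/C1=CCOC1=O` > 1700000 nM; compound 2 `C=C1CC[C@@H]2[C@](C)(COC(=O)c3cccnc3)[C@H](O)CC[C@@]2(C)[C@@H]1/C=C/C1=CCOC1=O` 113000 nM; compound 3 `C=C1CC[C@@H]2[C@](C)(COC(=O)c3cccs3)[C@H](O)CC[C@@]2(C)[C@@H]1/C=C/C1=CCOC1=O` 557000 nM.

In an ADME assay on HepG2 2.2.15 cells (Homo sapiens) for cytotoxicity, read by MTT assay (on this read-out higher numbers stand for lower toxicity in this test and lower numbers for higher toxicity in this test), compound 2 has the lowest number of the two numbers given. Compound 1 reached only a limit, (the limit of > 1700000 nM in this assay, at which 1 of the 3 values shown sits). Compound 4 `C=C1CC[C@@H]2[C@](C)(COC(C)=O)[C@H](O)CC[C@@]2(C)[C@@H]1/C=C/C1=CCOC1=O` differs from compound 2 in one place: methyl in place of pyridin-3-yl on a carbonyl carbon. Within the data shown here, the one measured step at this carbonyl carbon, a 4.9-fold higher number from compound 2 to compound 3 (0.69 log units; beyond the scatter), raised the number modestly, and compound 1 sits at the limit, so compound 4 is expected to give a higher number than compound 2, a step of about a 3.1-fold higher number from compound 2 to compound 4 (0.49 log units; beyond the scatter). The estimate for compound 4 is 350000 nM, within 90000 nM to 1500000 nM.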

Compound 4, half-maximal cytotoxic concentration: 225000 nM
The estimate for compound 4 lay 1.6-fold (0.19 log units) above the measured number; low and high end bracket the measured number.
By their numbers in this assay, from the lowest: compounds 2 and 4 (each within the scatter of the next); then compound 3. At a limit, above all of these: compound 1.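

In this assay the ring at this carbonyl carbon proves dispensable, since methyl in place of pyridin-3-yl gives a 2.0-fold higher number from compound 2 to compound 4 (0.30 log units; within the scatter) and the two compounds cannot be told apart. The thiophen-2-yl ester does not match this, as methyl in its place gives a 2.5-fold lower number from compound 3 to compound 4 (0.39 log units; beyond the scatter) and so the presence of a ring alone does not set the number. Compound 1 gives only a limit and not a number, and its steps cannot be read: the limit of > 1700000 nM in this assay, at which 1 of the 4 values shown sits.

Still open, from the compounds shown here alone, is where an amine or a carboxylic acid on this carbonyl carbon would fall. Going by these compounds, a longer chain in place of methyl is equally open.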